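The source may report more compounds than this note shows. Statements on the series, on what has been measured and on what is new or still open speak of the compounds shown alone.

In a physicochemical assay for solubility, read by HPLC, using the shake flask method, in phosphate buffer, with a stated time of 2 h, at pH 6.5 (a lower number here means a less soluble compound, a higher number a more soluble compound), three compounds that share one core have been measured so far. Compound 1 (`Nc1ncc(-c2ccc(C(=O)N3CC(O)C3)cc2)nc1-c1ccc(C(F)(F)F)cc1`) gives 55000 nM, compound 2 (`Nc1ncc(-c2ccc(C(=O)N3CC[C@@H](O)C3)cc2)nc1-c1ccc(C(F)(F)F)cc1`) gives 90000 nM, and compound 3 (`Nc1ncc(-c2ccc(C(=O)O)cc2)nc1-c1ccc(C(F)(F)F)cc1`) gives 95000 nM. Compound 3 therefore sits level with the other two, all within the usual scatter of repeat measurements. Compound 4 (`Nc1ncc(-c2ccc(C(=O)N3CCC(O)CC3)cc2)nc1-c1ccc(C(F)(F)F)cc1`) differs from compound 3 in one place, with 4-hydroxypiperidin-1-yl in place of hydroxy on a carbonyl carbon. The closest measured swaps at this carbonyl carbon are a 1.7-fold higher number from compound 1 to compound 3 (0.24 log units; within the scatter) and a 1.1-fold higher number from compound 2 to compound 3 (0.02 log units; within the scatter), and exchanging the two hydroxylated rings gave a 1.6-fold higher number from compound 1 to compound 2 (0.21 log units; within the scatter). All of these stay within the scatter, so no step beyond it is expected in this assay. The expected step is a 1.4-fold lower number from compound 3 to compound 4 (0.13 log units; within the scatter). The estimate for compound 4 is 70000 nM, with an expected range from 35000 nM to 120000 nM.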

Compound 4, solubility: 19000 nM
Compound 4: middle estimate off by 3.7-fold (0.57 log units), on the high side; the whole stated range lies above it.
By their numbers in this assay, from the lowest: compound 4; then compounds 1, 2 and 3 (each within the scatter of the next).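

In this assay, the swaps among carboxy, 3-hydroxyazetidin-1-yl and 3-hydroxypyrrolidin-1-yl on the carbonyl carbon all stayed within the scatter, so this position could have seemed tolerant of any such change. 4-Hydroxypiperidin-1-yl shows that it is not, with a 5.0-fold lower number from compound 3 to compound 4 (0.70 log units; beyond the scatter) and a 4.7-fold lower number from compound 2 to compound 4 (0.68 log units; beyond the scatter) and also a 2.9-fold lower number from compound 1 to compound 4 (0.46 log units; beyond the scatter). No supporting measurement accounts for this drop. On these data alone, whether it follows from the six-membered ring itself or from where its hydroxy sits stays open. Also open, as far as these compounds go, is how an amine bearing a longer open chain would compare on this carbonyl carbon.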